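Cytotoxicity of a Sulfonate Series in HEL Cells

The source may hold more compounds than are shown below. What is called first, only, known or untested is meant among the compounds shown, and "the series" means these compounds.

Three compounds built on the shared core of compound 1 `CCC1(Cc2ccccc2)OS(=O)(=O)C=C1OCC#N` have been examined in an ADME assay on HEL cells (Homo sapiens) for cytotoxicity, with a stated time of 3 days; on this read-out higher numbers stand for lower toxicity in this test and lower numbers for higher toxicity in this test. In this assay compound 1 gives only a limit, > 400000 nM. Compound 2 `CCC1(Cc2ccccc2)OS(=O)(=O)C=C1OCC1CCCCC1` likewise reaches only a limit in this assay, >= 200000 nM. Compound 3 `CCC1(Cc2ccccc2)OS(=O)(=O)C=C1OCc1ccc([N+](=O)[O-])cc1` also yields a limit rather than a number in this assay, >= 80000 nM. Compound 3 therefore stands among three values that are all limits; none of the three is a measured number, and the evidence consists of the limit of > 400000 nM in this assay, at which 1 of the 3 values shown sits, the limit of >= 200000 nM in this assay, at which 1 of the 3 values shown sits, and (the limit of >= 80000 nM in this assay, at which 1 of the 3 values shown sits).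

For that reason the measured steps cannot be read: a step that the two limits leave unreadable from compound 1 to compound 2, a step that the two limits leave unreadable from compound 1 to compound 3 and a step that the two limits leave unreadable from compound 2 to compound 3 all remain of unknown size and direction.

The next compound, compound 4 `CCC1(Cc2ccccc2)OS(=O)(=O)C=C1OCCCc1ccccc1`, differs from compound 3 in one place: phenethyl in place of 4-nitrophenyl on a saturated chain carbon bound to an oxygen on an unsaturated carbon. Among the measured compounds shown here, the three steps already measured bear on this change only in that none of them produced a readable number, so no size of step can be derived from them. The expected step is a step that the limit leaves unreadable from compound 3 to compound 4, with a further limit a likely outcome. Compound 4 is therefore estimated at 100000 nM in this assay, within a range from 30000 nM to 400000 nM.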

Compound 4, minimum cytotoxic concentration: >= 20000 nM
Compound 4: a limit, no number; the forecaster's own chance of this, stated with the estimate: 70%; the middle value is on the limit's open side.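

Like compound 1, compound 2 and compound 3, compound 4 gives only a limit in this assay, so its steps from those three compounds cannot be read in either size or direction. The compounds shown leave open whether exchanging these groups changes the minimum cytotoxic concentration at all, since none of the four has a measured number.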